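A few compounds are considered here, and "the series" means these few. Any claim that something is new, unique, unknown or untested is made for them only; others in the source may bear on it.

Compound 1 `[O-]/[N+](=C\c1cn(-c2ccccc2)nn1)c1ccccc1` and compound 2 `CCCCCCCCCCn1cc(/C=[N+](\[O-])c2ccccc2)nn1` have both been tested in a functional assay on COLO 205 cells (Homo sapiens) for inhibition, read by MTT assay, with a stated time of 24 h; on this read-out higher numbers stand for weaker inhibition and lower numbers for stronger inhibition. In this assay compound 1 gives > 100000 nM, which is a limit of the assay and not a measured number. In this assay compound 2 gives > 100000 nM, again a limit rather than a number. Among the measured compounds shown here, both results fall under (the limit of > 100000 nM in this assay, at which 2 of the 2 values shown sit), so compound 2 stands at the same limit as the only other compound tested, and no step between measured compounds can be drawn from these two values.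

Compound 3 `CCCCCCCCCCn1cc(/C=[N+](\[O-])C(C)(C)C)nn1` has not yet been tested in this assay. It differs from compound 2 by tert-butyl in place of phenyl on a double-bonded nitrogen. For the measured compounds named here, with the two tested compounds sitting at the limit and no measured step to build on, there is no basis for expecting this change to bring the half-maximal inhibitory concentration inside the measured range; the expectation for this assay is a step of no size beyond the scatter, which here means staying at the limit. Compound 3 is therefore estimated at 100000 nM, with a range from 40000 nM to 300000 nM. The step that this estimate means, a number no higher from compound 2 to compound 3 (the limit leaves the size open), is expected to lie within the scatter.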

Compound 3, half-maximal inhibitory concentration: 22100 nM
Beside the measured number, compound 3's estimate is 4.5-fold (0.66 log units) above it; the whole stated range lies above it.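

In this assay, tert-butyl in place of phenyl on the double-bonded nitrogen is the only change shown that brings a compound inside the measured range, with an at least 4.5-fold lower number from compound 2 to compound 3 (0.65 log units; beyond the scatter). From the compounds shown here alone, this shows that the group at this position matters: with the rest of the molecule unchanged, a result that could be reported only as a limit becomes a measured number, although the full size of the step remains unknown. Compound 3 therefore offers the only measured value so far, while the other results shown remain at the limit of the assay: the limit of > 100000 nM in this assay, at which 2 of the 3 values shown sit.

Going by these compounds, one step cannot tell what it is about tert-butyl that matters, so it remains open whether an isopropyl group, a cyclohexyl ring or a smaller methyl group on the same nitrogen would give a lower number, a higher one or a return to the limit. On these data alone, it is also open whether tert-butyl would give a measurable number when joined to a different chain at the other end of the molecule, such as a shorter hexyl chain or a longer dodecyl chain.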